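A Longer Amide Chain Tried on a Second Core

The compounds below may be only part of what the source reports. "The series", "measured", "known", "first", "only" and "open" are said of these compounds alone.

Compound 1 `CNC(=O)CCCCCCCn1nc(-c2cnc3[nH]ccc3c2)c2c(N)ncnc21` gives 51000 nM in a functional assay on A549 cells (Homo sapiens) for inhibition, read by MTT assay, with a stated time of 72 h; a lower number here means a stronger inhibitor, a higher number a weaker inhibitor.
Compound 2 `Nc1ncnc2c1c(-c1cnc3[nH]ccc3c1)nn2CC(=O)NO` reaches only a limit, > 150000 nM, in this assay.
Compound 3 `Nc1nc2cc(-c3nn(CC(=O)NO)c4ncnc(N)c34)ccc2o1` gives 27700 nM in this assay.

Compound 1 and compound 2 share a core and differ by 6-(methylcarbamoyl)hexyl in place of hydroxycarbamoyl on a saturated chain carbon bound to an aromatic nitrogen; the step is an at least 2.9-fold lower number from compound 2 to compound 1 (0.46 log units; beyond the scatter), and its size is bounded because of the limit of > 150000 nM in this assay, at which 1 of the 3 values shown sits. Compound 3 carries a different core, and the difference between the two cores is not broken down here. Compound 3 and compound 1 sit within the scatter of each other. Compound 4 `CNC(=O)CCCCCCCn1nc(-c2ccc3oc(N)nc3c2)c2c(N)ncnc21` is not yet measured; it differs from compound 3 by 6-(methylcarbamoyl)hexyl in place of hydroxycarbamoyl on a saturated chain carbon bound to an aromatic nitrogen, the same change. The step is expected to be a 2.8-fold lower number from compound 3 to compound 4 (0.44 log units; beyond the scatter), resting on compound 2 and compound 1, where the change gave an at least 2.9-fold lower number from compound 2 to compound 1 (0.46 log units; beyond the scatter). Compound 4 is therefore estimated at 10000 nM, between 3000 nM and 30000 nM.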

Compound 4, half-maximal inhibitory concentration: 8360 nM
Estimate against measurement, compound 4: 1.2-fold (0.08 log units) above; low and high end bracket the measured number.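

In this assay, the change to 6-(methylcarbamoyl)hexyl also lowers the number on the core of compound 3, a 3.3-fold lower number from compound 3 to compound 4 (0.52 log units; beyond the scatter), so the direction seen on the core of compound 1 carries over to a second core: the same change on two cores in this assay, an at least 2.9-fold lower number (0.46 log units; beyond the scatter) from compound 2 to compound 1 and a 3.3-fold lower number (0.52 log units; beyond the scatter) from compound 3 to compound 4; the limit leaves it open whether they differ. With this chain present on both cores, the swap of the aromatic group gives a 6.1-fold lower number from compound 1 to compound 4 (0.79 log units; beyond the scatter). Compound 2 gives a limit rather than a number, so the size of the change on its core stays unknown and equal size on the two cores is not shown: the limit of > 150000 nM in this assay, at which 1 of the 4 values shown sits.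

The change alters chain length and end group together, and the compounds shown leave open which of the two accounts for the step. A hydroxycarbamoyl on the longer chain, or a methylcarbamoyl on the short one, would separate them.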